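The source may report more compounds than this note shows. Statements on the series, on what has been measured and on what is new or still open speak of the compounds shown alone.

Measured compounds in a functional assay on Venous blood for antagonist activity at C-X-C chemokine receptor type 3 (Homo sapiens), read by flow cytometry, with a stated time of 30 min, in the presence of a further agent that is not named here; a higher number here means a weaker inhibitor, a lower number a stronger inhibitor:
Compound 1 `C[C@@H]1CN(c2sc(C(F)(F)F)nc2-c2nc3ccccc3[nH]2)CCN1C(=O)Cn1cccn1` gives 191 nM.
Compound 2 `Cc1nc(C)n(CC(=O)N2CCN(c3sc(C(F)(F)F)nc3-c3nc4ccc(OC5COC5)cc4[nH]3)C[C@H]2C)n1` gives 1480 nM.
Compound 3 `Cc1nc(C)n(CC(=O)N2CCN(c3sc(C(F)(F)F)nc3-c3nc4ccccc4[nH]3)C[C@H]2C)n1` gives 237 nM.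

Compound 3 holds the second highest number of the three. Compound 1 lies nearest, with a lower number that stays within the scatter; compound 2 lies furthest, with a higher number beyond the scatter. Exchanging the group on the saturated chain carbon bound to the carbonyl gave a 1.2-fold higher number from compound 1 to compound 3 (0.09 log units; within the scatter), so that part of the molecule has not moved the read-out. Removing the (oxetan-3-yl)oxy group from the six-membered aromatic ring of the fused system gave a 6.2-fold lower number from compound 2 to compound 3 (0.80 log units; beyond the scatter), a modest improvement.

Compound 4 `Cc1nc(C)n(CC(=O)N2CCN(c3sc(C(F)(F)F)nc3-c3nc4ccc(OC5CNC5)cc4[nH]3)C[C@H]2C)n1` is compound 3 carrying ((azetidin-3-yl)oxy in place of hydrogen on an aromatic carbon). Among the compounds with values here, the one step that bears on this is a 6.2-fold lower number from compound 2 to compound 3 (0.80 log units; beyond the scatter), the reverse change at the same position with a related four-membered ring holding one hetero atom. Within the data shown here, no compound with an (azetidin-3-yl)oxy group has been measured, so how far the nitrogen in place of the ring oxygen shifts the outcome is unknown. The expectation is a rise in the number of broadly similar size, a 4.2-fold higher number from compound 3 to compound 4 (0.63 log units; beyond the scatter), beyond the scatter. The estimate for compound 4 in this assay is 1000 nM, with a range from 350 nM to 3000 nM.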

Compound 4, half-maximal inhibitory concentration: 580 nM
Compound 4: middle estimate off by 1.7-fold (0.24 log units), on the high side; measured number inside the range.
By their numbers in this assay, from the lowest: compounds 1 and 3 (each within the scatter of the next); then compound 4; then compound 2.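

Both ether-linked four-membered rings on this aromatic carbon now sit on the weaker side of hydrogen in this assay: the step of a 2.4-fold higher number from compound 3 to compound 4 (0.39 log units; beyond the scatter) is smaller than the one seen with the oxetane, but it still lies beyond the scatter, so compound 3 keeps the lower number against both compound 2 and compound 4. The new information is that the outcome at this position depends on the ring and not only on the presence of an oxygen-linked substituent, since azetidin-3-yl in place of oxetan-3-yl on the same oxygen gives a 2.6-fold lower number from compound 2 to compound 4 (0.41 log units; beyond the scatter). Nothing available accounts for this difference between the two rings.

Still open, as far as these compounds go, is whether a methoxy group, a dimethylamino chain or a carboxylic acid on this aromatic carbon would stay close to compound 3, and whether an azetidine carrying a methyl or acetyl group on its nitrogen would read like compound 4 or compound 2. Also open, from the compounds shown here alone, is whether the (azetidin-3-yl)oxy group has the same effect when 1H-pyrazol-1-yl, as in compound 1, replaces 3,5-dimethyl-1H-1,2,4-triazol-1-yl.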